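The source may hold more compounds than are shown below. What is called first, only, known or untested is meant among the compounds shown, and "the series" means these compounds.

Of the compounds shown here, three built on one shared core have so far been measured in a physicochemical assay for solubility; on this read-out higher numbers stand for higher solubility and lower numbers for lower solubility. Compound 2 `COc1cc(NC(C)CCCN2C(=O)CN(C(=O)[C@@H](C)N)C2(C)C)c2ncccc2c1` gives 120000 ug/mL, the highest of the three numbers. Compound 3 `COc1cc(NC(C)CCCN2C(=O)[C@@H](C)NC2(C)C)c2ncccc2c1` gives 29800 ug/mL, and compound 1 `COc1cc(NC(C)CCCN2C(=O)CN(C(=O)[C@H](N)CCSC)C2(C)C)c2ncccc2c1` gives 11700 ug/mL, the lowest of the set. Going by the values given here, only one measured step alters the same chain carbon that matters here: from compound 1 to compound 2 the change brings a 10-fold higher number from compound 1 to compound 2 (1.01 log units; beyond the scatter), the number rising sharply once the side group on that carbon is removed entirely. Compound 4 `COc1cc(NC(C)CCCN2C(=O)CN(C(=O)[C@H](N)C(C)C)C2(C)C)c2ncccc2c1` carries the change (isopropyl in place of methyl on a saturated chain carbon bound to an amine nitrogen and a carbonyl carbon). That step goes the other way, placing a larger group back onto the same carbon, though one smaller than the side group of compound 1. The expectation is therefore a drop beyond the scatter, yet smaller than the measured step, and compound 4 is estimated at 35000 ug/mL, with a range from 12000 ug/mL to 100000 ug/mL. Expressed as a step, that expectation reads a 3.4-fold lower number from compound 2 to compound 4 (0.54 log units; beyond the scatter).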

Compound 4, solubility: 46500 ug/mL
Compound 4: the middle estimate sits 1.3-fold (0.12 log units) below what was measured; the range from low to high includes it.
By their numbers in this assay, from the lowest: compound 1; then compounds 3 and 4 (each within the scatter of the next); then compound 2.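

In this assay, the saturated chain carbon bound to an amine nitrogen and a carbonyl carbon now has a third side group, and its number falls between the other two. Isopropyl in place of methyl brings a 2.6-fold lower number from compound 2 to compound 4 (0.41 log units; beyond the scatter), while isopropyl in place of 2-(methylsulfanyl)ethyl brings a 4.0-fold higher number from compound 1 to compound 4 (0.60 log units; beyond the scatter), so both steps lie beyond the scatter. A sulfur-free, branched group therefore also reads lower than methyl, though not as low as 2-(methylsulfanyl)ethyl, and no supporting data explain this order. Going by these compounds alone, with only three side groups compared, the order is no general rule. From the compounds shown here alone, it remains open where an unbranched propyl chain would fall relative to isopropyl, and how a side group ending in a carboxylic acid or a phenyl ring would read.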